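Nitro for methyl on the benzoate ring of a terpenoid ester

This account rests on a few compounds, and the source may have more. Where it says the series, first, only, none or still open, it means among the compounds named here.

Three compounds have been measured in a functional assay on MCF7 cells (Homo sapiens) for antiproliferative activity, read by sulforhodamine B assay, with a stated time of 48 h, tested at 50 uM; on this read-out higher numbers stand for more inhibition at the one concentration tested (going by the name of the read-out) and lower numbers for less inhibition:

compound 1, `CC1=CC[C@H](C(C)C)c2cc(C)c(OC(=O)c3ccc(C)cc3)cc21`, giving 65%
compound 2, `CC1=CC[C@H](C(C)C)c2cc(C)c(OC(=O)c3ccc([N+](=O)[O-])cc3)cc21`, giving 72.9%
compound 3, `CC1=CC[C@H](C(C)C)c2cc(C)c(OC(=O)c3cccc(C)c3)cc21`, giving 54.9%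

Compound 2 differs from compound 1 by nitro in place of methyl on an aromatic carbon, and in this assay the step is a number 7.9 percentage points higher from compound 1 to compound 2 (within the scatter). Compound 3 differs from compound 1 by 3-methylphenyl in place of 4-methylphenyl on a carbonyl carbon, with a step of a number 10.1 percentage points lower from compound 1 to compound 3 (beyond the scatter), and against compound 2 the step is a number 18 percentage points lower from compound 2 to compound 3 (beyond the scatter).

Compound 4, `CC1=CC[C@H](C(C)C)c2cc(C)c(OC(=O)c3cccc([N+](=O)[O-])c3)cc21`, has not yet been measured. It differs from compound 3 by nitro in place of methyl on an aromatic carbon. This is the same kind of change as that from compound 1 to compound 2, but the place is not the same: in compound 2 the nitro stands para to a large group, in compound 4 meta to a large group. Since the earlier step, a number 7.9 percentage points higher from compound 1 to compound 2 (within the scatter), lay within the scatter, the step from compound 3 to compound 4 is expected to be similar, a number 5.1 percentage points higher from compound 3 to compound 4 (within the scatter). Compound 4 is therefore estimated at 60%, between 45% and 76%.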

Compound 4, a percentage reported as inhibition, at one concentration (the size of the read-out at that concentration, not a potency): 29.3%
Beside the measured number, compound 4's estimate is 30.7 percentage points above it, outside the stated range (below it).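

In this assay, nitro in place of methyl did not carry over from one core to the other, and the two steps differ: the same change on two cores in this assay, a number 7.9 percentage points higher (within the scatter) from compound 1 to compound 2 and a number 25.6 percentage points lower (beyond the scatter) from compound 3 to compound 4, 33.5 percentage points apart, beyond the scatter of two such steps

The drop on the second core is a number 25.6 percentage points lower from compound 3 to compound 4 (beyond the scatter), and the position of the nitro also separates the two nitro esters, with a number 43.6 percentage points lower from compound 2 to compound 4 (beyond the scatter), while the step from the first methyl ester is a number 35.7 percentage points lower from compound 1 to compound 4 (beyond the scatter). This shows that, in this series, the result of the change cannot be assumed to hold once the substituent is moved around the ring, but it rests on one pair per core and does not establish a rule for other groups or explain the reversal.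

The compounds shown leave open whether an amine, a carboxylic acid or a chlorine atom in place of the nitro would also give steps that differ between the two cores. They also leave open how these inhibition values relate to potency, as each compound is read at a single concentration.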